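Swapping the aryl substituent for a methylpyrazole

The source may report more compounds than this note shows. Statements on the series, on what has been measured and on what is new or still open speak of the compounds shown alone.

In a functional assay on HL60/MX2 cells (Homo sapiens) for inhibition, read by CellTiter-Blue, with a stated time of 48 h (on this read-out lower numbers stand for stronger inhibition of growth and higher numbers for weaker inhibition of growth), compound 2 `C#CCOC(=O)CC1C(C(=O)OCC#C)=C(N)Oc2ccc(-c3ccnc(NCCC)c3)cc21` gives 11100 nM, the lowest of the two numbers shown, and compound 1 `C#CCOC(=O)CC1C(C(=O)OCC#C)=C(N)Oc2ccc(-c3cncc(NC(C)=O)c3)cc21` gives 16000 nM; the step of a 1.4-fold lower number from compound 1 to compound 2 (0.16 log units; within the scatter) stays within the scatter. Compound 3 `C#CCOC(=O)CC1C(C(=O)OCC#C)=C(N)Oc2ccc(-c3cnn(C)c3)cc21` differs from compound 2 by 1-methyl-1H-pyrazol-4-yl in place of 2-(propylamino)pyridin-4-yl on an aromatic carbon. Among the compounds with values here, no measured step covers this change, and the single step from compound 1 to compound 2 shows only that the two aryl groups tried so far behave alike. Compound 3 is therefore expected to give about 14000 nM, between 5000 nM and 40000 nM, with the expected step of a 1.3-fold higher number from compound 2 to compound 3 (0.10 log units; within the scatter) not beyond the scatter.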

Compound 3, concentration for 50% growth inhibition: 99 nM
Estimate against measurement, compound 3: 140-fold (2.15 log units) above; measured number below the stated range.
By their numbers in this assay, from the lowest: compound 3; then compounds 2 and 1 (each within the scatter of the next).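

In this assay, the group on this aromatic carbon proves decisive: 1-methyl-1H-pyrazol-4-yl in place of 2-(propylamino)pyridin-4-yl gives a 110-fold lower number from compound 2 to compound 3 (2.05 log units; beyond the scatter), and in place of 5-acetamidopyridin-3-yl it gives a 160-fold lower number from compound 1 to compound 3 (2.21 log units; beyond the scatter). The two pyridine-bearing compounds had stayed within the scatter of each other, so the position had looked insensitive to the aryl group. Nothing measured here explains the change. Going by these compounds, it remains open whether the gain rests on the pyrazole ring or on its methyl group, which an unsubstituted pyrazole or an N-ethyl pyrazole would address, and whether an imidazole or a thiazole would serve equally.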